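The source may report more compounds than this note shows. Statements on the series, on what has been measured and on what is new or still open speak of the compounds shown alone.

Among the measured compounds shown here, in an ADME assay on the whole organism (plasma) for pharmacokinetics, with Rattus norvegicus as the target, at a dose of 3 mg/kg by the oral route (on this read-out higher numbers stand for higher exposure at the dose given and lower numbers for lower exposure), compound 2 (`CC(C)(C)NC(=O)N[C@H](C(=O)N1C[C@H]2[C@@H]([C@H]1C(=O)NC(CC1CC(F)(F)C1)C(=O)C(N)=O)C2(C)C)C(C)(C)C`) gives 611 ng.h/mL and holds the higher of the two numbers so far, while compound 1 (`CC(C)(C)NC(=O)N[C@H](C(=O)N1C[C@H]2[C@@H]([C@H]1C(=O)NC(CC1(F)CCC1)C(=O)C(N)=O)C2(C)C)C(C)(C)C`) gives 167 ng.h/mL on the same read-out. The next change is 2,2,2-trifluoroethyl in place of 3,3-difluorocyclobutyl on a saturated chain carbon, two bonds along the chain from an amide-type nitrogen and a carbonyl carbon and it leads to compound 3 (`CC(C)(C)NC(=O)N[C@H](C(=O)N1C[C@H]2[C@@H]([C@H]1C(=O)NC(CCC(F)(F)F)C(=O)C(N)=O)C2(C)C)C(C)(C)C`), with 2,2,2-trifluoroethyl in place of 3,3-difluorocyclobutyl on a saturated chain carbon, so that the chain no longer carries a ring.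

For the measured compounds named here, only one measured step bears on this: a 3.7-fold higher number from compound 1 to compound 2 (0.56 log units; beyond the scatter) at the same place, a modest move beyond the scatter. Going by the values given here, that step swaps one cyclobutyl-bearing group for another, and no measured compound lacks the ring, so the read-across is weak. It shows that exposure can respond to a change at this place, but it does not fix a direction for this one. With compound 2 at the top of a very short range, a modest fall in this assay is the more likely outcome, of about the size of the measured step or smaller. The estimated change is a 2.4-fold lower number from compound 2 to compound 3 (0.39 log units; beyond the scatter) and it carries wide uncertainty. The expected value for compound 3 is 250 ng.h/mL with 80 ng.h/mL to 750 ng.h/mL as the estimated range.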

Compound 3, area under the concentration-time curve: 11 ng.h/mL
The estimate for compound 3 lay 23-fold (1.36 log units) above the measured number; the measured number lies below the stated range.
By their numbers in this assay, from the lowest: compound 3; then compound 1; then compound 2.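

In this assay the saturated chain carbon, two bonds along the chain from an amide-type nitrogen and a carbonyl carbon, turns out to be far more sensitive than the earlier pair indicated: the large step of a 56-fold lower number from compound 2 to compound 3 (1.74 log units; beyond the scatter) outstrips the modest 3.7-fold higher number from compound 1 to compound 2 (0.56 log units; beyond the scatter) at the same place. The other comparison with the open chain is also large, at a 15-fold lower number from compound 1 to compound 3 (1.18 log units; beyond the scatter), so among these compounds both ring-bearing groups give higher numbers than 2,2,2-trifluoroethyl, with none of the three going against this. Nothing available bears on the cause of this loss of exposure.

In these steps the ring and the fluorine count change together, which leaves open whether the four-membered ring itself or the fluorine pattern tracks with the difference. As far as these compounds go, an unsubstituted cyclobutyl group or a non-fluorinated propyl chain at this place would begin to separate the two, and the size of the ring remains open as well, for example with a cyclopropyl or a cyclopentyl group.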